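Removing one amino group from compound 1

The source may hold more compounds than are shown below. What is called first, only, known or untested is meant among the compounds shown, and "the series" means these compounds.

Measured so far in a functional assay on DU-145 cells (Homo sapiens) for cytotoxicity, read by trypan blue exclusion, with a stated time of 96 h (a lower number here means a stronger inhibitor, a higher number a weaker inhibitor), with these results:
- compound 1 `COc1cc(OC)c(/C=C/S(=O)(=O)Nc2cc(N)c(OC)c(N)c2)c(OC)c1` at 2500 nM
- compound 2 `COc1ccc(/C=C/S(=O)(=O)Nc2ccc(F)cc2)cc1` at 10000 nM
- compound 3 `COc1ccc(NS(=O)(=O)/C=C/c2c(OC)cc(O)cc2OC)cc1` at 10000 nM

Compound 1 has the lowest number of the three. Compound 2 and compound 3 give the same value, and each lies higher than compound 1 by a margin beyond the scatter. Among the measured compounds shown here, no two measured compounds differ in one place only, so no measured step is available as a guide.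

The next compound is compound 4 `COc1cc(OC)c(/C=C/S(=O)(=O)Nc2ccc(OC)c(N)c2)c(OC)c1` which departs from compound 1 by hydrogen in place of amino on an aromatic carbon in the form of hydrogen in place of amino on an aromatic carbon, ortho to a methoxy group and meta to a large group. A lower number is expected in this assay with a large step beyond the scatter, though this is a judgement and not a measured trend. It rests on compound 1 at 2500 nM being the lowest so far and on one amino group remaining in compound 4. The estimated change is a 63-fold lower number from compound 1 to compound 4 (1.80 log units; beyond the scatter) with considerable uncertainty in its size. Compound 4 is expected at 40 nM with an estimated range from 6 nM to 600 nM as the working figure.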

Compound 4, half-maximal inhibitory concentration: 5 nM
Compound 4: the middle estimate sits 8.0-fold (0.90 log units) above what was measured, and the stated range ends above it.
By their numbers in this assay, from the lowest: compound 4; then compound 1; then compounds 2 and 3 (each within the scatter of the next).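

In this assay, hydrogen in place of amino on an aromatic carbon, ortho to a methoxy group and meta to a large group, gives a 500-fold lower number from compound 1 to compound 4 (2.70 log units; beyond the scatter), the first single-place step available in the series and one far beyond the scatter. This carbon is therefore highly sensitive to substitution, and a second amino group on the ring is not required for a low number, since compound 4 keeps only the amino group meta to the changed carbon and reaches 5 nM. Among the compounds shown here, no measurement available here bears on why this change lowers the number so far.

Still open, as far as these compounds go, is whether hydrogen is specifically favoured at this carbon or whether a fluorine atom, a hydroxyl group or a methyl group would give a similarly low number. Also open, from the compounds shown here alone, are whether the remaining amino group can be replaced by hydrogen, a hydroxyl group or an acetamide, and whether a step of this size would recur on a different core, since this reading rests on one pair of compounds.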